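A few compounds are considered here, and "the series" means these few. Any claim that something is new, unique, unknown or untested is made for them only; others in the source may bear on it.

Measured so far in a functional assay on K562 cells (Homo sapiens) for cytotoxicity, read by trypan blue exclusion, with a stated time of 96 h; a lower number here means a stronger inhibitor, a higher number a weaker inhibitor:
- compound 1 `COc1ccc(NS(=O)(=O)/C=C/c2c(OC)cccc2OC)cc1` gives 5000 nM
- compound 2 `COc1ccc(NS(=O)(=O)/C=C/c2c(OC)cc(OC)cc2OC)cc1` gives 75 nM

Going by the values given here, compound 2 holds the lower of the two numbers, and it is separated from compound 1 by the only measured step, a 67-fold lower number from compound 1 to compound 2 (1.82 log units; beyond the scatter), in which methoxy takes the place of hydrogen on an aromatic carbon. Compound 3 `COC(=O)C(C)(C)Nc1cc(NS(=O)(=O)/C=C/c2c(OC)cc(OC)cc2OC)ccc1OC` differs from compound 2 by (1-(methoxycarbonyl)-1-methylethyl)amino in place of hydrogen on an aromatic carbon, ortho to a methoxy group and meta to a large group. Among the compounds with values here, the step to compound 2 is large, but it involves only methoxy, and no measured step tests a group like this one. A moderate rise in the number in this assay is therefore expected, far smaller than that step, though the direction is uncertain. For compound 3 the expected value is 150 nM, with an estimated range from 30 nM to 1000 nM. This amounts to an expected 2.0-fold higher number from compound 2 to compound 3 (0.30 log units; within the scatter).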

Compound 3, half-maximal inhibitory concentration: 300 nM
The estimate for compound 3 lay 2.0-fold (0.30 log units) below the measured number; low and high end bracket the measured number.
By their numbers in this assay, from the lowest: compound 2; then compound 3; then compound 1.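

In this assay this aromatic carbon, ortho to a methoxy group and meta to a large group, gives its first reading, with (1-(methoxycarbonyl)-1-methylethyl)amino bringing a 4.0-fold higher number from compound 2 to compound 3 (0.60 log units; beyond the scatter) and so a weaker inhibitor, though only a modest step. The one earlier step, a 67-fold lower number from compound 1 to compound 2 (1.82 log units; beyond the scatter) in the same assay, concerned methoxy at another place in the molecule and said nothing about this carbon, which is shown here to accept a group of this size with a loss that stays modest. No measurement at hand explains why the number rises at this position.

The compounds shown leave open which part of the entering group accounts for the step, since a plain amine or the carboxylic acid in place of the methyl ester could separate the nitrogen from the ester. They also leave open whether a small group such as fluorine or hydroxyl on this carbon would move the number at all.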